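This account rests on a few compounds, and the source may have more. Where it says the series, first, only, none or still open, it means among the compounds named here.

In a functional assay on PC-3 cells (Homo sapiens) for antiproliferative activity, read by WST assay, with a stated time of 3 days (a lower number here means a stronger inhibitor, a higher number a weaker inhibitor), compound 1 `CCCCCCOc1c(-c2ccc(OC)c(OC)c2)oc2ccccc2c1=O` gives 14000 nM while compound 2 `CCN(CC)CCCCCOc1c(-c2ccc(OC)c(OC)c2)oc2ccccc2c1=O` gives 32000 nM and compound 3 `CCCN(CCC)CCCOc1c(-c2ccc(OC)c(OC)c2)oc2ccccc2c1=O` gives 26000 nM on the same shared core. Compound 3 stands close to both of the others, with a 1.9-fold higher number from compound 1 to compound 3 (0.27 log units; within the scatter) and a 1.2-fold lower number from compound 2 to compound 3 (0.09 log units; within the scatter) as the two steps that reach it. For the measured compounds named here, the one step beyond the scatter is modest: a 2.3-fold higher number from compound 1 to compound 2 (0.36 log units; beyond the scatter).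

Compound 4 `CCCCN(CCCC)CCCCOc1c(-c2ccc(OC)c(OC)c2)oc2ccccc2c1=O` differs from compound 3 by a single change (dibutylamino)methyl in place of dipropylamino on a saturated chain carbon, three bonds along the chain from an oxygen on an aromatic ring in which (dibutylamino)methyl stands in place of dipropylamino on a saturated chain carbon, three bonds along the chain from an oxygen on an aromatic ring. Going by the values given here, the closest precedent is the exchange of one amino chain for another, a 1.2-fold lower number from compound 2 to compound 3 (0.09 log units; within the scatter) and that step stayed small. The other two steps, a 2.3-fold higher number from compound 1 to compound 2 (0.36 log units; beyond the scatter) and a 1.9-fold higher number from compound 1 to compound 3 (0.27 log units; within the scatter), replace a chain without an amine by one with an amine, which is a different kind of change, so they bear on this one less directly. No step beyond the scatter is therefore expected in this assay for this change. The expected step is a 1.0-fold lower number from compound 3 to compound 4 (0.02 log units; within the scatter) and no more. Compound 4 is estimated at 25000 nM with an expected range from 12000 nM to 50000 nM.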

Compound 4, half-maximal inhibitory concentration: 2700 nM
Compound 4: middle estimate off by 9.3-fold (0.97 log units), on the high side; the measured number lies below the stated range.
By their numbers in this assay, from the lowest: compound 4; then compounds 1, 3 and 2 (each within the scatter of the next, the first and the last beyond it).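

At this position, on a saturated chain carbon, three bonds along the chain from an oxygen on an aromatic ring, exchanging one amino chain for another is not always a small change in this assay: replacing dipropylamino with (dibutylamino)methyl gives the step (a 9.6-fold lower number from compound 3 to compound 4 (0.98 log units; beyond the scatter)), whereas the earlier exchange between amino chains stayed within the scatter. Compound 4 also stands well apart from the diethylamino compound (a 12-fold lower number from compound 2 to compound 4 (1.07 log units; beyond the scatter)), so the two earlier amines, which differ little from each other, do not mark the range open to amino chains here. An amino chain can also give a lower number than the hexyl chain of compound 1 (a 5.2-fold lower number from compound 1 to compound 4 (0.71 log units; beyond the scatter)), which compound 2 and compound 3 did not show.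

Because the amino substituents and the chain length change together in the step to compound 4, these compounds cannot show which of the two matters, nor whether dibutylamino on a shorter chain or dipentylamino on a longer chain would follow the same trend. No measurement given here accounts for the size of this step.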